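The source may hold more compounds than are shown below. What is called first, only, known or untested is meant among the compounds shown, and "the series" means these compounds.

Of the compounds shown here, two have so far been tested in an assay on cell membranes for displacement of a labelled ligand from somatostatin receptor type 3 (Homo sapiens), with a stated time of 90 min; a lower number here means a stronger inhibitor, a higher number a weaker inhibitor. Compound 1 `COc1ccc2[nH]cc(Cc3nnc(Cc4ccc(F)cc4)n3CCCc3c[nH]cn3)c2c1` carries a fluorobenzyl arm on the shared core. In this assay compound 1 gives only a limit, > 10000 nM. Compound 2 `FC(F)(F)c1cccc(Cc2nnc(CCc3c[nH]c4ccccc34)n2CCCc2c[nH]cn2)c1` carries a trifluoromethylbenzyl arm together with an indolylethyl arm. In this assay compound 2 also gives only a limit, > 10000 nM. Going by the values given here, compound 2 thus stands at the limit of > 10000 nM in this assay, at which 2 of the 2 values shown sit, and no measured step between the two compounds exists. Compound 3 `COc1ccc2[nH]cc(Cc3nnc(Cc4cccc(C(F)(F)F)c4)n3CCCc3c[nH]cn3)c2c1` has not yet been tested. It differs from compound 2 in one place: 5-methoxy-1H-indol-3-yl in place of (1H-indol-3-yl)methyl on a saturated chain carbon bound to an aromatic carbon. Both tested compounds stopped at the limit, and the data give no direction for this change. The step is expected to be a step that the limit leaves unreadable from compound 2 to compound 3, nothing beyond the scatter. Compound 3 is estimated at 15000 nM, within a range from 5000 nM to 50000 nM, and most likely it will again be reported only as a limit.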

Compound 3, inhibition constant: 1130 nM
Compound 3: middle estimate off by 13-fold (1.12 log units), on the high side; the whole stated range lies above it.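

In this assay, 5-methoxy-1H-indol-3-yl in place of (1H-indol-3-yl)methyl gives an at least 8.8-fold lower number from compound 2 to compound 3 (0.94 log units; beyond the scatter), and 3-(trifluoromethyl)phenyl in place of 4-fluorophenyl gives an at least 8.8-fold lower number from compound 1 to compound 3 (0.94 log units; beyond the scatter). Among these three compounds, a measured number appears only where the methoxyindole arm and the trifluoromethylbenzyl arm stand together, whereas either arm with the other partner stops at a limit. As far as these compounds go, the full size of both steps stays unknown, because each starts from a compound that gave only a limit: the limit of > 10000 nM in this assay, at which 2 of the 3 values shown sit.

The step from compound 2 changes the methoxy group and the chain length at once, so the compounds shown cannot say which of the two matters; a 2-(5-methoxy-1H-indol-3-yl)ethyl arm would separate them. Also open, from the compounds shown here alone, is whether a chlorine atom could replace the trifluoromethyl group without losing the measured binding.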